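This account rests on a few compounds, and the source may have more. Where it says the series, first, only, none or still open, it means among the compounds named here.

Measured in a functional assay on MIA PaCa-2 cells (Homo sapiens) for cytotoxicity, read by MTT assay, with a stated time of 72 h; on this read-out higher numbers stand for an effect only at larger amounts of compound and lower numbers for an effect already at smaller amounts:
compound 1 `O=C1/C(=C\c2ccc(O)cc2)c2ccccc2N1c1c(Cl)cccc1Cl` gives 2 ug/mL
compound 2 `O=C1/C(=C\c2cccc(Br)c2)c2ccccc2N1c1c(Cl)cccc1Cl` gives 5 ug/mL

Within the data shown here, compound 2 stands at the higher of the two numbers; the only measured step, a 2.5-fold higher number from compound 1 to compound 2 (0.40 log units; beyond the scatter), lies beyond the scatter. Compound 3 `O=C1/C(=C\c2ccccc2Cl)c2ccccc2N1c1c(Cl)cccc1Cl` differs from compound 2 by 2-chlorophenyl in place of 3-bromophenyl on a double-bonded chain carbon bound to a double-bonded ring carbon. Among the measured compounds shown here, no measured step exchanges one halogenated phenyl for another; the single step known swaps a hydroxyphenyl for a bromophenyl and does not bear on this change. Compound 3 is therefore expected to show no step beyond the scatter in this assay, an estimated no change at the digits printed from compound 2 to compound 3 (within the scatter). The estimate for compound 3 is 5 ug/mL, within 2 ug/mL to 12 ug/mL.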

Compound 3, concentration for half-maximal effect: > 100 ug/mL
Compound 3: no number, only a limit; the forecaster's own chance of this, stated with the estimate: 5%; middle value at least 20-fold (1.30 log units) away from the limit.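

In this assay compound 3 has no number, only a limit of the assay: the limit of > 100 ug/mL in this assay, at which 1 of the 3 values shown sits.

Exchanging one halogenated phenyl for another on a double-bonded chain carbon bound to a double-bonded ring carbon is therefore not a neutral change, giving an at least 20-fold higher number from compound 2 to compound 3 (1.30 log units; beyond the scatter). Set against 4-hydroxyphenyl, 2-chlorophenyl gives an at least 50-fold higher number from compound 1 to compound 3 (1.69 log units; beyond the scatter), so this place moves the read-out far more than the first two compounds showed.

Since 3-bromophenyl and 2-chlorophenyl differ in both halogen and position, the compounds shown cannot separate the two. As far as these compounds go, how a phenyl bearing an amine or a carboxylic acid would behave in this assay also remains open.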